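The source may report more compounds than this note shows. Statements on the series, on what has been measured and on what is new or still open speak of the compounds shown alone.

Measured so far, in an ADME assay on the whole organism for inhibition, with Oryza sativa as the target, with a stated time of 4 days; on this read-out lower numbers stand for stronger inhibition and higher numbers for weaker inhibition:
compound 1 `CCN(c1nc(Cl)nc(N[C@@H](C)c2ccccc2)n1)C(C)C` gives 537 nM
compound 2 `C[C@@H](Nc1nc(Cl)nc(NC(C)(C)C)n1)c1ccccc1` gives 9330 nM
compound 3 `C[C@H](Nc1nc(Cl)nc(NC(C)(C)C)n1)c1ccccc1` gives 3310 nM

Compound 2 stands highest of the three numbers, which on this read-out means the weakest inhibition; its nearest neighbour is compound 3, a 2.8-fold lower number from compound 2 to compound 3 (0.45 log units; beyond the scatter), and the two share every atom and bond, differing only in how one stereocentre is drawn (the fact that compounds 2 and 3 differ only in the configuration as drawn). The largest gap separates it from compound 1.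

The compound not yet measured is compound 4 `CCNc1nc(Cl)nc(N[C@H](C)c2ccccc2)n1`. Going by the values given here, it keeps the configuration of compound 2 and changes only one group: ethyl in place of tert-butyl on a nitrogen on an aromatic ring.

Of the measured steps, the one that bears most on this change is the replacement of the amine substituent on the shared core: a 6.2-fold higher number from compound 1 to compound 3 (0.79 log units; beyond the scatter). There, a smaller and more branched pair of groups gave way to a single (tert-butyl)amino group, and the number rose. Among the compounds with values here, compound 4 moves the other way, trimming tert-butyl down to ethyl, so a decrease in the number is the more likely direction, though no measured pair shows exactly this ethyl group. The configuration step between compound 2 and compound 3 does not bear on the change itself.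

The expectation for compound 4 is a modest drop: a 3.1-fold lower number from compound 2 to compound 4 (0.49 log units; beyond the scatter). In this assay compound 4 is estimated at 3000 nM, with a likely range from 800 nM to 12000 nM.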

Compound 4, half-maximal inhibitory concentration: 14100 nM
Compound 4: middle estimate off by 4.7-fold (0.67 log units), on the low side, and the stated range ends below it.
By their numbers in this assay, from the lowest: compound 1; then compound 3; then compounds 2 and 4 (each within the scatter of the next).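

Going from (tert-butyl)amino to ethylamino on this nitrogen gives a 1.5-fold higher number from compound 2 to compound 4 (0.18 log units; within the scatter), so in this assay these two groups cannot be told apart, even though ethyl has fewer heavy atoms than tert-butyl. Simply having a group with fewer carbons at this place is therefore not enough to lower the number, whereas the only step at this place that lies beyond the scatter remains the one involving ethyl(isopropyl)amino, a 6.2-fold higher number from compound 1 to compound 3 (0.79 log units; beyond the scatter). This reading comes from compound 2 alone, as compound 3 carries the other drawn configuration: the fact that compounds 2 and 3 differ only in the configuration as drawn

The compounds shown leave open whether ethylamino would also match (tert-butyl)amino in the configuration of compound 3, and whether ethyl(isopropyl)amino keeps its advantage in the configuration of compound 2. They also leave open how a longer chain such as n-butyl, a ring such as cyclopropyl, or a group carrying a hydroxyl would behave on this nitrogen, so the trend at this place rests on very few groups.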